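Compound 3 to compound 4: replacing the benzoyl group

This account rests on a few compounds, and the source may have more. Where it says the series, first, only, none or still open, it means among the compounds named here.

In a functional assay on IMR-32 cells (Homo sapiens) for antiproliferative activity, with a stated time of 72 h (a lower number here means a stronger inhibitor, a higher number a weaker inhibitor), compound 3 `O=C(CCN(Cc1ccc(C(=O)NO)cc1)C(=O)c1ccccc1)NCc1ccccc1` gives 2360 nM, which lies within the scatter of compound 2 `Cc1cc(C)cc(C(=O)N(CCC(=O)NCc2ccccc2)Cc2ccc(C(=O)NO)cc2)c1` at 1390 nM. Compound 1 `Cc1ccc(NC(=O)CCN(Cc2ccc(C(=O)NO)cc2)C(=O)c2cc(C)cc(C)c2)cc1` stands apart at 210 nM, a lower number than either.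

Compound 4 `COc1cc(OC)cc(C(=O)N(CCC(=O)NCc2ccccc2)Cc2ccc(C(=O)NO)cc2)c1` differs from compound 3 at the benzoyl group: 3,5-dimethoxyphenyl in place of phenyl on a carbonyl carbon. In words, this is 3,5-dimethoxyphenyl in place of phenyl on a carbonyl carbon.

The closest measured change is at the same place: a 1.7-fold higher number from compound 2 to compound 3 (0.23 log units; within the scatter), with phenyl in place of 3,5-dimethylphenyl. That step does not exceed the scatter. The other step, a 6.6-fold higher number from compound 1 to compound 2 (0.82 log units; beyond the scatter), is larger, but it belongs to the amide-type nitrogen and does not bear on this change. For the measured compounds named here, no measured compound carries 3,5-dimethoxyphenyl, so the comparison remains indirect.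

In this assay, no step beyond the scatter is expected, and the estimated change is a 1.6-fold lower number from compound 3 to compound 4 (0.20 log units; within the scatter). Compound 4 is estimated at 1500 nM, with an expected range of 650 nM to 3300 nM.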

Compound 4, half-maximal inhibitory concentration: 6040 nM
Compound 4: middle estimate off by 4.0-fold (0.60 log units), on the low side; measured number above the stated range.
By their numbers in this assay, from the lowest: compound 1; then compounds 2 and 3 (each within the scatter of the next); then compound 4.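

In this assay the benzoyl position now gives a step beyond the scatter: a 2.6-fold higher number from compound 3 to compound 4 (0.41 log units; beyond the scatter). The earlier change at this place, phenyl for 3,5-dimethylphenyl, stayed within the scatter, whereas 3,5-dimethoxyphenyl in place of 3,5-dimethylphenyl on the same carbonyl carbon also separates beyond it, with a 4.3-fold higher number from compound 2 to compound 4 (0.64 log units; beyond the scatter), so these two disubstituted groups are not interchangeable in this series. No supporting measurement is available to account for the rise.

Going by these compounds, whether 3,5-difluorophenyl or 3,5-dichlorophenyl on this carbonyl carbon would read closer to compound 2 or to compound 4 remains open. Also open, on these data alone, is whether 3,5-dimethoxyphenyl would give a similar step with the 4-methylphenyl of compound 1 on the amide-type nitrogen.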